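A pyridinone ring in place of a fluoropyridine ring

The compounds below may be only part of what the source reports. "The series", "measured", "known", "first", "only" and "open" are said of these compounds alone.

Compound 2 `CCCCc1nc(=O)c(S(=O)(=O)c2ccc(-c3ccc(F)nc3)cc2)c(O)n1-c1c(OC)cccc1OC` was tested in an ADME assay on microsomes from liver (Homo sapiens) for metabolic stability, using NADPH, with a stated time of 10 min (a lower number here means that less of the compound is left, a higher number that more of the compound is left), where compound 2 gives 100%. Compound 1 `CCCCc1nc(=O)c(S(=O)(=O)c2ccc(-c3ccc(F)cc3)cc2)c(O)n1-c1c(OC)cccc1OC` gives 100% in this assay, and the step of no change at the digits printed from compound 1 to compound 2 (within the scatter) lies within the scatter. Compound 3 `CCCCc1nc(=O)c(S(=O)(=O)c2ccc(-n3cc(Cl)ccc3=O)cc2)c(O)n1-c1c(OC)cccc1OC` differs from compound 2 in one place: a group of 8 heavy atoms (5 carbon, 1 nitrogen, 1 oxygen, 1 chlorine; one six-membered aromatic ring with 1 hetero atom) in place of a group of 7 heavy atoms (5 carbon, 1 nitrogen, 1 fluorine; one six-membered aromatic ring with 1 hetero atom), on an aromatic carbon. Within the data shown here, only that one measured step concerns the same ring, and it showed nothing beyond the scatter. For compound 3 the expected step is therefore a number 5 percentage points lower from compound 2 to compound 3 (within the scatter), none beyond the scatter. Compound 3 is estimated at 95%, with a range from 80% to 100%.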

Compound 3, percent of the compound remaining: 94%
For compound 3 the middle estimate is 1 percentage points above the measured one; the range from low to high includes it.
By their numbers in this assay, from the lowest: compounds 3, 1 and 2 (each within the scatter of the next).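

Replacing the 6-fluoropyridin-3-yl group with a ring carrying a carbonyl and a chlorine gives a number 6 percentage points lower from compound 2 to compound 3 (within the scatter) in this assay, and the comparison with the 4-fluorophenyl group gives a number 6 percentage points lower from compound 1 to compound 3 (within the scatter). This position, para to a large group, therefore now has a third ring with no step beyond the scatter, and this ring has one more hydrogen-bond acceptor than the 6-fluoropyridin-3-yl group. Nothing available explains this result.

Going by these compounds, whether a group without a ring, such as an amine or a carboxylic acid, would also stay within the scatter here remains open.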